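The source may hold more compounds than are shown below. What is called first, only, known or untested is meant among the compounds shown, and "the series" means these compounds.

Measured compounds:
- compound 1, `S=C(N/N=C/c1ccc2ccccc2n1)Nc1cccc(Cl)c1`: 48100 nM in a functional assay on HT-29 cells (Homo sapiens) for antiproliferative activity, read by sulforhodamine B assay, with a stated time of 72 h; on this read-out lower numbers stand for stronger inhibition and higher numbers for weaker inhibition
- compound 2, `Cc1csc2sc(/C=N/NC(N)=S)c(C)c12`: 57500 nM
- compound 3, `CN(C)C(=S)N/N=C/c1ccc2cccnc2n1`: 410 nM

On this assay compound 1 stands second highest of the three numbers. Its nearest neighbour is compound 2, whose number is within the scatter of its own, so the two cannot be ranked. Compound 3 gives the lowest number of the three, and its gap to compound 1 lies beyond the scatter. Compound 4, `Fc1ccc(NC(=S)N/N=C/c2ccc3ccccc3n2)cc1`, has not yet been measured. It differs from compound 1 in one place: 4-fluorophenyl in place of 3-chlorophenyl on an amide-type nitrogen. For the measured compounds named here, no step between two measured compounds here makes the same kind of change, so the expectation rests on compound 1 alone, as an aryl-to-aryl swap on the same core. Compound 4 is expected to give 50000 nM, within 15000 nM to 150000 nM, meaning an expected step of a 1.0-fold higher number from compound 1 to compound 4 (0.02 log units; within the scatter) that stays within the scatter.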

Compound 4, half-maximal inhibitory concentration: 28500 nM
Estimate against measurement, compound 4: 1.8-fold (0.24 log units) above, within the range that was stated.
By their numbers in this assay, from the lowest: compound 3; then compounds 4, 1 and 2 (each within the scatter of the next).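

In this assay, placing 4-fluorophenyl in place of 3-chlorophenyl on the amide-type nitrogen gives a 1.7-fold lower number from compound 1 to compound 4 (0.23 log units; within the scatter) and so leaves the two compounds unranked. For the compounds shown here, this is the first measured step at this position, and it shows that this aryl-to-aryl swap on the shared core produces no change beyond the scatter. Nothing measured here explains this result.

Going by these compounds, it remains open whether the same holds for groups that are not phenyl rings, such as a cyclohexyl ring or a morpholine ring, at this nitrogen.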